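Sulfonylating the Phenol Oxygen: an Expectation for Compound 4

The source may hold more compounds than are shown below. What is called first, only, known or untested is meant among the compounds shown, and "the series" means these compounds.

Compound 1 `COc1ccc(/C=C/C(=O)c2ccc(OC)c3c2OC(C)(C)C=C3)cc1O`: 800 nM
Compound 2 `COc1ccc(/C=C/C(=O)c2ccc(OC)c3c2OC(C)(C)C=C3)cc1OCCO`: 9600 nM
Compound 3 `COc1ccc(/C=C/C(=O)c2ccc(OC)c3c2OC(C)(C)C=C3)cc1OCCCN(C)C`: 4100 nM

Measured in a functional assay on A-375 cells (Homo sapiens) for cytotoxicity, read by MTT assay (on this read-out lower numbers stand for stronger inhibition and higher numbers for weaker inhibition), compound 1 stands lowest of the three numbers, with compound 3 nearest and compound 2 furthest away. The step to compound 4 `COc1ccc(/C=C/C(=O)c2ccc(OC)c3c2OC(C)(C)C=C3)cc1OS(=O)(=O)c1ccc(C)cc1` is (4-methylphenyl)sulfonyl in place of hydrogen on an oxygen on an aromatic ring. Two measured steps start from the same compound and also replace that hydrogen with a larger group on the same oxygen: a 12-fold higher number from compound 1 to compound 2 (1.08 log units; beyond the scatter) and a 5.1-fold higher number from compound 1 to compound 3 (0.71 log units; beyond the scatter). Both moves weakened inhibition beyond the scatter, and the (4-methylphenyl)sulfonyl group is again a sizeable addition at that position, so a rise of comparable size is expected, namely a 7.5-fold higher number from compound 1 to compound 4 (0.88 log units; beyond the scatter). Compound 4 is therefore estimated at 6000 nM, expected to lie between 2000 nM and 20000 nM.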

Compound 4, half-maximal inhibitory concentration: 2400 nM
For compound 4 the middle estimate is 2.5-fold (0.40 log units) above the measured one; the measured number falls inside the stated range.
By their numbers in this assay, from the lowest: compound 1; then compounds 4 and 3 (each within the scatter of the next); then compound 2.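

Putting (4-methylphenyl)sulfonyl on this oxygen also weakens inhibition, giving a 3.0-fold higher number from compound 1 to compound 4 (0.48 log units; beyond the scatter) and making it the third group here to fall short of the free hydroxy. The entering group matters, since swapping 2-hydroxyethyl for it gives a 4.0-fold lower number from compound 2 to compound 4 (0.60 log units; beyond the scatter) while swapping 3-(dimethylamino)propyl for it gives a 1.7-fold lower number from compound 3 to compound 4 (0.23 log units; within the scatter) and so no real difference. No measurement here explains these differences. Going by these compounds, whether a group as small as methyl or acetyl on this oxygen would match compound 1 remains open.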